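Working notes: from compound 3 to compound 4

The source may report more compounds than this note shows. Statements on the series, on what has been measured and on what is new or still open speak of the compounds shown alone.

Of the compounds shown here, three have been read so far in a functional assay on HeLa cells (Homo sapiens) for antiproliferative activity, read by sulforhodamine B assay (a higher number here means a weaker inhibitor of growth, a lower number a stronger inhibitor of growth), and two of them give only limits. Compound 1 (`CC(=O)O[C@@H]1[C@@H](OCc2ccccc2)[C@H](OCc2ccccc2)[C@@H](COCc2ccccc2)O[C@H]1C`) gives > 50000 nM as a limit and not a number. Compound 3 (`C[C@@H]1O[C@H](COCc2ccccc2)[C@@H](OCc2ccccc2)[C@H](OCc2ccccc2)C1=O`) gives > 50000 nM as a limit and not a number. Compound 3 thus stands at the limit of > 50000 nM in this assay, at which 2 of the 3 values shown sit, and carries no number of its own. Within the data shown here, compound 2 (`CC(C)C[C@H]1O[C@H](COCc2ccccc2)[C@@H](OCc2ccccc2)[C@H](OCc2ccccc2)[C@H]1O`) bears an isobutyl group and gives 43900 nM as the only true number.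

Compound 4 (`CC(C)C[C@@H]1O[C@H](COCc2ccccc2)[C@@H](OCc2ccccc2)[C@H](OCc2ccccc2)C1=O`) differs from compound 3 by isopropyl in place of hydrogen on a saturated chain carbon bound to a saturated ring carbon and so turns methyl into isobutyl. Among the measured compounds shown here, no measured pair shows this change, so the expectation rests on compound 2 with its 43900 nM alone. In this assay the estimated step of an at least 1.2-fold lower number from compound 3 to compound 4 (0.09 log units; that floor lies within the scatter) is expected to be small and towards stronger growth inhibition, and a reading at the limit would be no surprise. Compound 4 is estimated at 40000 nM with an expected range from 20000 nM to 50000 nM in this read-out.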

Compound 4, concentration for 50% growth inhibition: > 50000 nM
Compound 4 was reported as a limit (the forecaster's own chance of this, stated with the estimate: 50%); middle value at least 1.2-fold (0.09 log units) from the limit.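

Compound 3 and compound 4 are both reported only as limits, so no step between them can be read: the limit of > 50000 nM in this assay, at which 3 of the 4 values shown sit.

The compounds shown leave open whether going from methyl to isobutyl on the shared core changes growth inhibition at all.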